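Chain length and a sulfur link in cyanoguanidine histamine analogues

The source may hold more compounds than are shown below. What is called first, only, known or untested is meant among the compounds shown, and "the series" means these compounds.

Measured compounds:
compound 1 `N#C/N=C(\NCCCc1ccccc1)NCCCc1c[nH]cn1`: 14100 nM
compound 2 `N#C/N=C(\NCCCCc1ccccc1)NCCCc1c[nH]cn1`: 8910 nM

Compounds 1 and 2 were tested in an in vitro functional assay on Sf9 cells for agonist activity at histamine H2 receptor (Homo sapiens); on this read-out higher numbers stand for an effect only at larger amounts of compound and lower numbers for an effect already at smaller amounts. In this assay compound 1 gives 14100 nM and compound 2 gives 8910 nM; the two numbers lie within the scatter of each other, so compound 2 stands on a par with compound 1, and nothing further separates them. For the measured compounds named here, the single measured step, a 1.6-fold lower number from compound 1 to compound 2 (0.20 log units; within the scatter), extends the aryl-bearing chain by one carbon and leaves the read-out essentially unchanged.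

Compound 3 `N#C/N=C(/NCCCc1c[nH]cn1)NCCSc1ccccc1` differs from compound 2 by phenylsulfanyl in place of phenethyl on a saturated chain carbon, two bonds along the chain from an amine nitrogen. Its chain between the amine nitrogen and the ring is thus shorter than that of compound 2, with a sulfur in place of a carbon. Going by the values given here, the only step that bears on this change is the chain-length step from compound 1 to compound 2, which was within the scatter. On that basis no step beyond the scatter is expected in this assay, and for compound 3 the estimated value is 10000 nM (range 3000 nM to 35000 nM), corresponding to an expected step of a 1.1-fold higher number from compound 2 to compound 3 (0.05 log units; within the scatter).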

Compound 3, half-maximal effective concentration: 7240 nM
Beside the measured number, compound 3's estimate is 1.4-fold (0.14 log units) above it; the range from low to high includes it.
By their numbers in this assay, from the lowest: compounds 3, 2 and 1 (each within the scatter of the next).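

In this assay, phenylsulfanyl in place of phenethyl at this position, on a saturated chain carbon, two bonds along the chain from an amine nitrogen, gives a 1.2-fold lower number from compound 2 to compound 3 (0.09 log units; within the scatter), and phenylsulfanyl in place of benzyl gives a 1.9-fold lower number from compound 1 to compound 3 (0.29 log units; within the scatter). Compounds 1 and 2 showed only a change of all-carbon chain length, whereas compound 3 shows that phenylsulfanyl, with its sulfur and one hydrogen-bond acceptor, stays on a par with both carbon-linked groups. No supporting evidence is available to explain this result.

The compounds shown leave open whether an ether oxygen in place of the sulfur, or a longer chain carrying the sulfur, would also stay on a par. They also leave open what an amine or a carboxylic acid on the phenyl ring would do to the read-out.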